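This account rests on a few compounds, and the source may have more. Where it says the series, first, only, none or still open, it means among the compounds named here.

Compound 1 `CCCCCCCCCCCCNC(=O)[C@@H](NC(=O)c1ccco1)[C@@H](C)O`: 147000 nM
Compound 2 `CCCCCCCCCCCCNC(=O)[C@@H](NC(=O)c1nccc2ccccc12)[C@@H](C)O`: 65700 nM
Compound 3 `CCCCCCCCCCCCNC(=O)[C@@H](NC(=O)/C=C/c1ccccc1)[C@@H](C)O`: a limit only, > 200000 nM

In a functional assay on HepG2 cells (Homo sapiens) for cytotoxicity, read by MTT assay, with a stated time of 48 h (a higher number here means a weaker inhibitor, a lower number a stronger inhibitor), compound 1 gives 147000 nM, while compound 2 gives 65700 nM; the change a 2.2-fold lower number from compound 1 to compound 2 (0.35 log units; beyond the scatter). For compound 3 the reading is not a number but a limit of the assay, > 200000 nM. Measured against the other two, an at least 3.0-fold higher number from compound 2 to compound 3 (0.48 log units; beyond the scatter) and an at least 1.3-fold higher number from compound 1 to compound 3 (0.13 log units; that floor lies within the scatter). Compound 3 therefore stands at the weak end of what has been measured, at the limit of > 200000 nM in this assay, at which 1 of the 3 values shown sits.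

Compound 4 `CCCCCCCCCCCCNC(=O)[C@@H](NS(=O)(=O)c1cccs1)[C@@H](C)O` differs from compound 3 in one place: (thiophen-2-yl)sulfonyl in place of (2-phenylethenyl)carbonyl on an amine nitrogen. Among the measured compounds shown here, the measured steps all swap one group for another on a carbonyl carbon and keep the carbonyl itself, whereas here the carbonyl linkage is replaced by a sulfonyl one; no measured step covers such a change. For the measured compounds named here, the steps that bear on the starting point, the ones into compound 3, both end at the limit, so the starting value may itself be well past the number reported. Without a guide for the new linkage, a step of no clear size in either direction is expected, and compound 4 is estimated to stay near the weak end, with a good chance of returning only a limit again: 180000 nM, between 70000 nM and 400000 nM, meaning an at least 1.1-fold lower number from compound 3 to compound 4 (0.04 log units; that floor lies within the scatter).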

Compound 4, half-maximal inhibitory concentration: 25900 nM
Estimate against measurement, compound 4: 6.9-fold (0.84 log units) above; measured number outside the range, below it.
By their numbers in this assay, from the lowest: compound 4; then compound 2; then compound 1. At a limit, above all of these: compound 3.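

Among the compounds shown here, every earlier step kept the carbonyl on the amine nitrogen and changed only the group attached to it, so these results are the first to show what happens when a sulfonyl linkage takes its place. In this assay, the new linkage with its thiophen-2-yl ring does not push the compound towards the weak end of the series, giving an at least 7.7-fold lower number from compound 3 to compound 4 (0.88 log units; beyond the scatter) and a 5.7-fold lower number from compound 1 to compound 4 (0.75 log units; beyond the scatter). The first of these steps is only a floor, because the reading for compound 3 is a limit and not a number: the limit of > 200000 nM in this assay, at which 1 of the 4 values shown sits.

Each step to compound 4 changes the linkage and the attached group together, so the shift cannot be assigned to the sulfonyl or to the thiophene ring alone; a (thiophen-2-yl)carbonyl or a phenylsulfonyl group on the same nitrogen would separate the two. Also open, from the compounds shown here alone, is whether the sulfonyl linkage would give a similar result with other groups on it, such as furan-2-yl or isoquinolin-1-yl, or whether this result belongs to the thiophene ring alone.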